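Fluorine Added Where Cytotoxicity Already Sits at the Limit

The source may hold more compounds than are shown below. What is called first, only, known or untested is meant among the compounds shown, and "the series" means these compounds.

Compound 1 `CCN(c1ccccc1)S(=O)(=O)c1cc(Cl)ccc1Cl` is the starting point. In an ADME assay on A549 cells (Homo sapiens) for cytotoxicity, read by MTT assay (on this read-out lower numbers stand for higher toxicity in this test and higher numbers for lower toxicity in this test), compound 1 gives > 5000 nM, which is a limit of the assay rather than a number. Compound 2 `CCN(c1ccc(F)cc1)S(=O)(=O)c1cc(Cl)ccc1Cl` differs from compound 1 by fluoro in place of hydrogen on an aromatic carbon. In this assay compound 2 gives > 5000 nM, again a limit. Between the two stands a step that the two limits leave unreadable from compound 1 to compound 2. Compound 3 `CCN(c1ccc(Cl)cc1F)S(=O)(=O)c1cc(Cl)ccc1Cl` carries a different core; the difference between the two cores is not broken down here. In this assay compound 3 gives > 5000 nM, also a limit. All measured values therefore share (the limit of > 5000 nM in this assay, at which 3 of the 3 values shown sit).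

Compound 4 `CCN(c1c(F)cc(Cl)cc1F)S(=O)(=O)c1cc(Cl)ccc1Cl` is not yet measured and differs from compound 3 by fluoro in place of hydrogen on an aromatic carbon. Among the measured compounds shown here, this is the same kind of change as the one from compound 1 to compound 2, though not the same: there the fluoro entered para to a large group, here it enters ortho to a large group, meta to a chloro group and meta to a fluoro group. No step size can be carried over, since the earlier step is not readable. The expected step is a step that the limit leaves unreadable from compound 3 to compound 4, which keeps the value at the limit. This expectation rests on (the limit of > 5000 nM in this assay, at which 3 of the 3 values shown sit). The estimate for compound 4 in this assay is 10000 nM.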

Compound 4, half-maximal cytotoxic concentration: > 5000 nM
Compound 4 gave a limit, no number; the forecaster's own chance of this, stated with the estimate: 90%; the middle value does not contradict the limit.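

In this assay compound 4 gives > 5000 nM, a limit and not a number. Compound 3 also sits at a limit, so the step from compound 3 to compound 4 cannot be read. The compounds shown leave open where each true value lies beyond the limit, and whether adding fluoro changes cytotoxicity at all.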